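This account rests on a few compounds, and the source may have more. Where it says the series, first, only, none or still open, it means among the compounds named here.

In a functional assay on CFPAC-1 cells (Homo sapiens) for antiproliferative activity, read by MTT assay, with a stated time of 72 h (on this read-out higher numbers stand for weaker inhibition and lower numbers for stronger inhibition), compound 1 `CCCCCc1ccc(C#Cc2c(-c3ccc(CCCCC)cc3)oc3nc(=O)n(Cc4cn(-c5ccc(Cl)cc5)nn4)cc23)cc1` gives only a limit, > 100000 nM. Compound 2 `CCCCCc1ccc(C#Cc2c(-c3ccc(CCCCC)cc3)oc3nc(=O)n(Cc4cn(Cc5ccccc5)nn4)cc23)cc1` likewise gives only a limit, > 100000 nM. The step that the two limits leave unreadable from compound 2 to compound 1 is thus unreadable; the change is 4-chlorophenyl in place of benzyl on an aromatic nitrogen. Both values sit at the limit of > 100000 nM in this assay, at which 2 of the 3 values shown sit, so this pair tells nothing about the size of the change. Among the compounds with values here, compound 3 `O=c1nc2oc(CCCCl)cc2cn1Cc1cn(Cc2ccccc2)nn1` is the only member with a number, giving 23500 nM in this assay. The difference between the core of compound 3 and the core of compound 2 is not broken down here. Compound 4 `O=c1nc2oc(CCCCl)cc2cn1Cc1cn(-c2ccc(Cl)cc2)nn1` carries the same change as compound 1: 4-chlorophenyl in place of benzyl on an aromatic nitrogen. The measured step that the two limits leave unreadable from compound 2 to compound 1 gives no readable size, so the expectation rests only on compound 3 and its 23500 nM. The expected step is a 1.1-fold lower number from compound 3 to compound 4 (0.03 log units; within the scatter), small. Compound 4 is estimated at 22000 nM, spanning 7000 nM to 70000 nM.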

Compound 4, half-maximal inhibitory concentration: > 100000 nM
Compound 4 ended at the assay's limit; the forecaster's own chance of this, stated with the estimate: 15%; at least 4.5-fold (0.65 log units) between middle value and limit.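

In this assay, 4-chlorophenyl in place of benzyl on an aromatic nitrogen gives an at least 4.2-fold higher number from compound 3 to compound 4 (0.62 log units; beyond the scatter), so on the core of compound 3 the change weakens inhibition. Compound 4 gives only a limit, > 100000 nM. The same change on the core of compound 2 cannot be read, so nothing shows whether it acts alike on both cores, and the step on the core of compound 3 has only a lower bound: the limit of > 100000 nM in this assay, at which 3 of the 4 values shown sit.

A phenyl or a 4-chlorobenzyl on that aromatic nitrogen would separate the chlorine from the change in the link to the ring. As far as these compounds go, how either group would read on the core of compound 3 in this assay remains open.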